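Branched ether chain replaces cyclopropylmethyl on the amide nitrogen

The source may report more compounds than this note shows. Statements on the series, on what has been measured and on what is new or still open speak of the compounds shown alone.

Compound 3 `O=C(CN(CC1CC1)C(=O)c1ccc(-c2ccccn2)cc1)Nc1cc(F)cc(F)c1` carries a cyclopropylmethyl group on an amide-type nitrogen. In an assay on HEK293 cells for inhibition of sodium- and chloride-dependent glycine transporter 1 (Homo sapiens), read by scintillation proximity assay (a higher number here means a weaker inhibitor, a lower number a stronger inhibitor), compound 3 gives 200 nM. Of the two numbers available this is the lower; the nearest number belongs to compound 1 `O=C(CN(C(=O)c1ccccc1Cl)C1CCCCC1)Nc1cc(F)cc(F)c1`, which in this assay gives 20000 nM, and the gap between these two lies well beyond the usual scatter. Compound 2 `COc1ccc(C(=O)N(Cc2[nH]ncc2-c2ccccc2)C2CCCCC2)cc1` is recorded only as a limit of the assay: in this assay compound 2 gives > 25100 nM, which is a limit and not a number (the limit of > 25100 nM in this assay, at which 1 of the 3 values shown sits).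

Compound 4 `CCC(COC)N(CC(=O)Nc1cc(F)cc(F)c1)C(=O)c1ccc(-c2ccccn2)cc1` has not been measured. It differs from compound 3 in one place: 1-(methoxymethyl)propyl in place of cyclopropylmethyl on an amide-type nitrogen. Among the compounds with values here, no pair of measured compounds differs in only this way, and compound 1 and compound 3 differ in several places at once, so their gap cannot be assigned to the group on the nitrogen alone. The expectation is a modest step in the weakening direction from compound 3 to compound 4 , on the order of a 2.5-fold higher number from compound 3 to compound 4 (0.40 log units; beyond the scatter), not far beyond the scatter. Compound 4 is therefore estimated at 500 nM in this assay, with a plausible range from 120 nM to 2000 nM.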

Compound 4, half-maximal inhibitory concentration: 1260 nM
Compound 4: middle estimate off by 2.5-fold (0.40 log units), on the low side; measured number inside the range.
By their numbers in this assay, from the lowest: compound 3; then compound 4; then compound 1. At a limit, above all of these: compound 2.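

In this assay, within the data shown here, the swap on the amide-type nitrogen gives the first reading of a single change at this position: a 6.3-fold higher number from compound 3 to compound 4 (0.80 log units; beyond the scatter), with 1-(methoxymethyl)propyl in place of cyclopropylmethyl. The position is therefore not indifferent to the group it carries, although the size of this step is modest and compound 4 still gives a measured number rather than a limit. The change is also a bundle of differences, since the three-membered ring leaves, the group grows from 4 to 6 heavy atoms, and an ether oxygen enters as a hydrogen-bond acceptor.

This one step cannot separate those differences, and a carbon-only chain such as 1-ethylpropyl on the same nitrogen, set against compound 3 and compound 4, would show whether the ether oxygen matters or whether the loss of the ring and the larger size are enough to account for the shift. The measurements shown include nothing that speaks to the reason for this step.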